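The source may hold more compounds than are shown below. What is called first, only, known or untested is meant among the compounds shown, and "the series" means these compounds.

Measured so far:

Compound 1 `CN(C)CCCn1c(N)c(-c2nc3ccccc3[nH]2)c2nc(C#N)c(C#N)nc21` — 870 nM
Compound 2 `CCN(CC)CCCn1c(N)c(-c2nc3ccccc3[nH]2)c2nc(C#N)c(C#N)nc21` — > 730 nM
Compound 3 `CN(C)CCn1c(N)c(-c2nc3cc(Cl)ccc3[nH]2)c2nc(C#N)c(C#N)nc21` — > 50000 nM

All three were tested in a functional assay on HL-60 cells (Homo sapiens) for antiproliferative activity, read by MTT assay, with a stated time of 48 h; on this read-out lower numbers stand for stronger inhibition and higher numbers for weaker inhibition. Compound 1 gives 870 nM. For compound 2 the assay reports only a limit, > 730 nM, so its true value is not known as a number. The change from compound 1 to compound 2 is diethylamino in place of dimethylamino on a saturated chain carbon, three bonds along the chain from an aromatic nitrogen, and the step it made, a step that the limit leaves unreadable from compound 1 to compound 2, cannot be read in size because one end sits at the limit of > 730 nM in this assay, at which 1 of the 3 values shown sits.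

Compound 3 also comes back only as a limit, > 50000 nM, at the limit of > 50000 nM in this assay, at which 1 of the 3 values shown sits. How the core of compound 3 differs from that of compound 1 is not broken down here.

Compound 4 `CCN(CC)CCn1c(N)c(-c2nc3cc(Cl)ccc3[nH]2)c2nc(C#N)c(C#N)nc21` has not yet been measured. It differs from compound 3 by diethylamino in place of dimethylamino on a saturated chain carbon, two bonds along the chain from an aromatic nitrogen. This is the same kind of change as that from compound 1 to compound 2, though the place differs: two bonds along the chain from an aromatic nitrogen rather than three.

Among the measured compounds shown here, the only measured example of this change left no readable step, and compound 3 itself sits at a limit. The step from compound 3 to compound 4 is therefore expected to be small, about a step that the limit leaves unreadable from compound 3 to compound 4, and compound 4 is estimated in this assay at 60000 nM, between 20000 nM and 200000 nM, most likely again reported as a limit.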

Compound 4, half-maximal inhibitory concentration: > 50000 nM
Compound 4 ended at the assay's limit; the forecaster's own chance of this, stated with the estimate: 80%; the middle value lies beyond the limit too.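

Compound 3 and compound 4 both stop at the same limit in this assay, so neither has a number and no step can be read between them: the limit of > 50000 nM in this assay, at which 2 of the 4 values shown sit.

The compounds shown leave open whether diethylamino in place of dimethylamino changes the activity at all, and how strongly compound 2, compound 3 and compound 4 truly inhibit the cells.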